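A few compounds are considered here, and "the series" means these few. Any claim that something is new, unique, unknown or untested is made for them only; others in the source may bear on it.

Metabolic stability is the question here, and the compounds share one core. In an ADME assay on microsomes from liver (Homo sapiens) for metabolic stability, read by LC-MS, using NADPH, tested at 1 uM (a lower number here means that the compound disappears faster, a higher number that the compound lasts longer), compound 1 `CN(C/C=C\CN)C[C@H]1O[C@@H](n2cnc3c(N)ncnc32)[C@@H]2OC(C)(C)O[C@@H]21` gives > 1.5 h, which is a limit of the assay and not a number. Compound 2 `Cc1nc2c(N)ncnc2n1[C@@H]1O[C@H](CN(C/C=C\CN)C2CC2)[C@H]2OC(C)(C)O[C@H]21` gives > 1.5 h, again a limit. Compound 3 `CNc1ncnc2c1ncn2[C@@H]1O[C@H](CN(C)C/C=C\CN)[C@H]2OC(C)(C)O[C@H]21` gives > 1.5 h, and this too is a limit. The whole series so far is therefore summed up as the limit of > 1.5 h in this assay, at which 3 of the 3 values shown sit, and no exact half-life is known for any of these compounds.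

Compound 4 `CN(C/C=C\CN)C[C@H]1O[C@@H](n2cnc3cncnc32)[C@@H]2OC(C)(C)O[C@@H]21` departs from compound 3 in one place: hydrogen in place of methylamino on an aromatic carbon. The methylamino group leaves, and a hydrogen takes its place on an aromatic carbon.

Among the compounds with values here, only one measured step touches this group: a step that the two limits leave unreadable from compound 1 to compound 3, in which a methyl replaces a hydrogen on a nitrogen on an aromatic ring. Within the data shown here, no measured step removes the group altogether, so there is no measured size to carry over. The expectation leans instead on compound 3, whose > 1.5 h is a limit. In this assay, no step beyond the usual scatter is expected, and neither direction is favoured, so the estimated change is a step that the limit leaves unreadable from compound 3 to compound 4. Compound 4 is estimated at 1.6 h, with an expected range from 0.9 h to 3 h. The assay may well report only a limit again.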

Compound 4, half-life: > 1.5 h
Compound 4 was reported as a limit; the forecaster's own chance of this, stated with the estimate: 70%; the middle value is on the limit's open side.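

Compound 4 is reported only as a limit, as are compound 1 and compound 3, so the steps from compound 3 and from compound 1 to compound 4 cannot be read. All the compounds shown stand at the same place: the limit of > 1.5 h in this assay, at which 4 of the 4 values shown sit. Still open, on these data alone, is each compound's actual half-life, and so whether amino, methylamino or hydrogen on that aromatic carbon changes it.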